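A Second Ring Nitrogen on a Weakly Active Analogue

A few compounds are considered here, and "the series" means these few. Any claim that something is new, unique, unknown or untested is made for them only; others in the source may bear on it.

Compound 2 `COc1ccccc1S(=O)(=O)/C=C/c1cccnc1` is one of three compounds that share a common core and differ only in the aromatic ring attached to the double-bonded chain carbon. In an assay on U2OS cells for activation of nuclear factor erythroid 2-related factor 2 (Homo sapiens), read by chemiluminescence, with a stated time of 6 h (on this read-out higher numbers stand for an effect only at larger amounts of compound and lower numbers for an effect already at smaller amounts), compound 2 gives only a limit of the assay, > 10000 nM, and not a number. Compound 1 `COc1ccccc1S(=O)(=O)/C=C/c1ccccn1` gives 9070 nM in this assay, and the change from pyridin-2-yl to pyridin-3-yl, an at least 1.1-fold higher number from compound 1 to compound 2 (0.04 log units; that floor lies within the scatter), stays within the scatter. Compound 3 `COc1ccccc1S(=O)(=O)/C=C/c1cccnc1Cl` has chloro in place of hydrogen on an aromatic carbon relative to compound 2; compound 3 gives 849 nM, so that an at least 11-fold lower number from compound 2 to compound 3 (1.07 log units; beyond the scatter). Compound 2 thus sits at the limit of > 10000 nM in this assay, at which 1 of the 3 values shown sits.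

Compound 4 `COc1ccccc1S(=O)(=O)/C=C/c1cncnc1` differs from compound 2 by pyrimidin-5-yl in place of pyridin-3-yl on a double-bonded chain carbon bound to a double-bonded chain carbon. Among the compounds with values here, none of the measured steps adds a second ring nitrogen; the nearest comparison, an at least 1.1-fold higher number from compound 1 to compound 2 (0.04 log units; that floor lies within the scatter), moved a ring nitrogen without an effect beyond the scatter, while an at least 11-fold lower number from compound 2 to compound 3 (1.07 log units; beyond the scatter) concerns a chloro group and does not carry over to this change. Compound 4 is therefore expected to remain close to where compound 2 stands, with an expected step that the limit leaves unreadable from compound 2 to compound 4. The estimate for compound 4 is 15000 nM, with a range from 5000 nM to 50000 nM, and the result may again be reported only as a limit.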

Compound 4, half-maximal effective concentration: > 10000 nM
Compound 4 ended at the assay's limit (the forecaster's own chance of this, stated with the estimate: 60%); the middle value is on the limit's open side.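

Setting pyrimidin-5-yl in place of pyridin-3-yl on the double-bonded chain carbon adds a second ring nitrogen, and in this assay compound 4 gives a limit of the assay, not a number, just as compound 2 does: the limit of > 10000 nM in this assay, at which 2 of the 4 values shown sit. Within the data shown here, the two limits leave the step between these compounds unreadable, but the new result does show that this second ring nitrogen does not bring a number into the measurable range, something the earlier compounds could not show. The comparison with the pyridin-2-yl analogue gives an at least 1.1-fold higher number from compound 1 to compound 4 (0.04 log units; that floor lies within the scatter), so the measured floor does not separate that pair.

Chloro on the pyridin-3-yl ring gave an at least 11-fold lower number from compound 2 to compound 3 (1.07 log units; beyond the scatter), and whether the same group would bring a similar gain on the pyrimidin-5-yl ring remains open. On these data alone, it is also open whether an amine or a fluoro group on either ring, in place of that chloro, would bring a number into the measurable range of this assay.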